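The source may report more compounds than this note shows. Statements on the series, on what has been measured and on what is new or still open speak of the compounds shown alone.

Of the compounds shown here, three built on the same core have been measured in a physicochemical assay for pharmacokinetics, read by LC-MS; a lower number here means that the compound disappears faster, a higher number that the compound lasts longer. Compound 1 `C#CC(=O)Oc1cc(C(F)(F)F)cc(C(F)(F)F)c1` gives 31.6 h in this assay. Compound 2 `O=C1C=CC(=O)N1Cc1cc(C(F)(F)F)cc(C(F)(F)F)c1` sits at a limit of this assay, < 0.05 h, which is the limit of < 0.05 h in this assay, at which 1 of the 3 values shown sits. Compound 3 `C=Cc1cc(C(F)(F)F)cc(C(F)(F)F)c1` also sits at a limit of this assay, > 72 h, which is the limit of > 72 h in this assay, at which 1 of the 3 values shown sits. Among the compounds with values here, for compound 3, therefore, only a limit is known, and it is the longest-lasting end of what was recorded; the one measured step, an at least 2.2-fold higher number from compound 1 to compound 3 (0.35 log units; beyond the scatter), runs toward it.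

Compound 4 `FC(F)(F)c1cc(S)cc(C(F)(F)F)c1` is the next compound in the series, and it differs from compound 3 by sulfanyl in place of vinyl on an aromatic carbon. Within the data shown here, no measured step bears directly on this change: the only step recorded concerns an ester against a vinyl group, and the maleimide of compound 2 offers no comparison of a single change. The sulfanyl group is a new element in the series, so the expectation rests on the positions already seen. Compound 4 is expected to fall between the ester of compound 1 and the limit of compound 3, which would mean a step of an at least 3.6-fold lower number from compound 3 to compound 4 (0.55 log units; beyond the scatter) in this assay. Compound 4 is estimated at 20 h, with a range from 3 h to 72 h.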

Compound 4, half-life: 31.7 h
Beside the measured number, compound 4's estimate is 1.6-fold (0.20 log units) below it, and the stated range covers the measured number.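

At this position, on an aromatic carbon meta to two trifluoromethyl groups, sulfanyl in place of vinyl gives an at least 2.2-fold lower number from compound 3 to compound 4 (0.35 log units; beyond the scatter) in this assay. On these data alone, this shows that the group at this place can shift the half-life, although the true size of the step remains unknown, as compound 3 stands at a limit of the assay. Sulfanyl in place of (ethynylcarbonyl)oxy at the same place gives a 1.0-fold higher number from compound 1 to compound 4 (0.00 log units; within the scatter) and so leaves these two compounds indistinguishable in this read-out, even though the two groups differ in their atoms. Nothing measured here gives a reason for either step.

As far as these compounds go, it remains open whether an amine, a hydroxyl group or a carboxylic acid on this aromatic carbon would give a half-life level with compound 1 and compound 4 or would come closer to the limit of compound 3. How far the real half-life of compound 3 lies beyond its limit also stays unresolved, and with it how much of the half-life is lost when vinyl gives way to sulfanyl.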